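Amide aryl variation in the flavonol series: ethyl for difluoro

The compounds below may be only part of what the source reports. "The series", "measured", "known", "first", "only" and "open" are said of these compounds alone.

Compound 3 `O=C(Nc1cccc(-c2oc3cc(-c4ccc(F)cc4)ccc3c(=O)c2O)c1)c1ccc(F)cc1F` gives the highest of the three numbers in a functional assay on HeLa cells (Homo sapiens) for antiproliferative activity, read by CCK-8 assay, with a stated time of 72 h (on this read-out lower numbers stand for stronger inhibition and higher numbers for weaker inhibition), at 10700 nM. Compound 1 `O=C(Nc1cccc(-c2oc3cc(-c4ccc(F)cc4)ccc3c(=O)c2O)c1)c1ccccc1F` stands nearest with 5630 nM, and compound 2 `COc1ccc(C(=O)Nc2cccc(-c3oc4cc(-c5ccc(F)cc5)ccc4c(=O)c3O)c2)cc1` furthest with 4820 nM. The step of a 1.9-fold higher number from compound 1 to compound 3 (0.28 log units; within the scatter) stays within the scatter, whereas a 2.2-fold higher number from compound 2 to compound 3 (0.35 log units; beyond the scatter) lies beyond it, and a 1.2-fold lower number from compound 1 to compound 2 (0.07 log units; within the scatter) does not separate the two lower compounds.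

Compound 4 `CCc1ccc(C(=O)Nc2cccc(-c3oc4cc(-c5ccc(F)cc5)ccc4c(=O)c3O)c2)cc1` carries 4-ethylphenyl in place of 2,4-difluorophenyl on a carbonyl carbon. Among the compounds with values here, two measured steps bear on this change: a 2.2-fold higher number from compound 2 to compound 3 (0.35 log units; beyond the scatter) shows that moving from a 4-methoxyphenyl amide to the 2,4-difluorophenyl amide raises the number modestly, and a 1.9-fold higher number from compound 1 to compound 3 (0.28 log units; within the scatter) shows that fluoro in place of hydrogen on the amide aryl changes little. The move to 4-ethylphenyl removes both fluorines and restores an amide aryl with a single substituent, as in compound 2. A downward step of modest size, a 1.9-fold lower number from compound 3 to compound 4 (0.29 log units; within the scatter), is therefore expected for compound 4. Compound 4 is estimated at 5500 nM, with a range from 2500 nM to 12000 nM.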

Compound 4, half-maximal inhibitory concentration: 21000 nM
The estimate for compound 4 lay 3.8-fold (0.58 log units) below the measured number; the measured number lies above the stated range.
By their numbers in this assay, from the lowest: compounds 2, 1, 3 and 4 (each within the scatter of the next, the first and the last beyond it).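

In this assay, ethyl in place of methoxy on an aromatic carbon gives a 4.4-fold higher number from compound 2 to compound 4 (0.64 log units; beyond the scatter), so a single substituent on the amide aryl does not by itself keep the number low: compound 2 and compound 4 both carry one, and the choice of group separates them. The 4-ethylphenyl amide also stands apart from the 2-fluorophenyl amide, with a 3.7-fold higher number from compound 1 to compound 4 (0.57 log units; beyond the scatter), while a 2.0-fold higher number from compound 3 to compound 4 (0.29 log units; within the scatter) does not separate it from the 2,4-difluorophenyl amide. No measurement shown here accounts for the difference between ethyl and methoxy.

On these data alone, it remains open how an unsubstituted phenyl, or a longer chain such as propyl in place of ethyl, would read at this position. As far as these compounds go, an amine or a carboxylic acid on the amide aryl also remains open.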